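Removing Both Bromines from a Dibromobenzamide Series

The source may report more compounds than this note shows. Statements on the series, on what has been measured and on what is new or still open speak of the compounds shown alone.

Compound 1 `COc1c(Br)cccc1C(=O)Nc1ccccc1` gives > 100000 nM in an assay on isolated protein for inhibition of thiosulfate sulfurtransferase (Homo sapiens), with a stated time of 60 min, in the absence of a further agent; a higher number here means a weaker inhibitor, a lower number a stronger inhibitor.
Compound 2 `O=C(Nc1ccc(Sc2nc3ccccc3s2)c(Cl)c1)c1cc(Br)cc(Br)c1` gives > 100000 nM in this assay.
Compound 3 `O=C(Nc1ccc(Sc2nc3ccccc3s2)cc1)c1cc(Br)cc(Br)c1` gives > 100000 nM in this assay.

Each of these three values is a limit of this assay rather than a measured number, so compound 3 stands only at that limit (the limit of > 100000 nM in this assay, at which 3 of the 3 values shown sit). Among the compounds with values here, the single one-point comparison among the measured compounds, a step that the two limits leave unreadable from compound 2 to compound 3, cannot be read in size for the same reason. Compound 4 `O=C(Nc1ccc(Sc2nc3ccccc3s2)cc1)c1ccccc1` differs from compound 3 by phenyl in place of 3,5-dibromophenyl on a carbonyl carbon. Within the data shown here, no measured step shows what this change does, and all three known values sit at the limit (the limit of > 100000 nM in this assay, at which 3 of the 3 values shown sit), so the most that can be expected for compound 4 is another limit. Compound 4 is therefore estimated at 100000 nM, with a range from 30000 nM to 300000 nM. The expected step of a number no higher from compound 3 to compound 4 (the limit leaves the size open) is none beyond the scatter.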

Compound 4, half-maximal inhibitory concentration: > 100000 nM
Compound 4: only a limit was reported; the forecaster's own chance of this, stated with the estimate: 85%; the middle value sits exactly at the limit.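

In this assay, within the data shown here, compound 4 gives > 100000 nM as a limit and not a number, so no step from compound 3 to compound 4 can be read. The compounds shown leave open which structure would give a measured number in this assay at all.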